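The source may report more compounds than this note shows. Statements on the series, on what has been measured and on what is new or still open speak of the compounds shown alone.

Compound 1 `O=c1cc(-c2ccc(O)c(O)c2)oc2cc(OCCO)ccc12` is one of two measured compounds in a functional assay for inhibition, with Rattus norvegicus as the target, using microsomes (on this read-out higher numbers stand for weaker inhibition and lower numbers for stronger inhibition), where compound 1 gives 16400 nM, the lowest of the two numbers. Within the data shown here, compound 2 `C[N+](C)(C)CCCOc1ccc2c(=O)cc(-c3ccc(O)c(O)c3)oc2c1` gives 37300 nM in this assay, and the only measured step, a 2.3-fold higher number from compound 1 to compound 2 (0.36 log units; beyond the scatter), concerns a different place on the molecule. Compound 3 `O=c1c(O)c(-c2ccc(O)c(O)c2)oc2cc(OCCO)ccc12` differs from compound 1 by hydroxy in place of hydrogen on an aromatic carbon. Among the measured compounds shown here, no measured step addresses this change, so the data give no direction for it. Compound 3 is therefore expected to show at most a small step, a 1.4-fold lower number from compound 1 to compound 3 (0.14 log units; within the scatter), and is estimated at 12000 nM, within 4000 nM to 40000 nM.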

Compound 3, half-maximal inhibitory concentration: 13800 nM
Compound 3: the middle estimate sits 1.2-fold (0.06 log units) below what was measured; low and high end bracket the measured number.
By their numbers in this assay, from the lowest: compounds 3 and 1 (each within the scatter of the next); then compound 2.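

In this assay, hydroxy in place of hydrogen on this aromatic carbon, ortho to the 3,4-dihydroxyphenyl group, gives a 1.2-fold lower number from compound 1 to compound 3 (0.07 log units; within the scatter) and so leaves the read-out within the scatter. Unlike the earlier step, which concerned the chain on the other side of the molecule, this gives a first reading at this position: here the added hydroxy brings no change that can be told from repeat variation. Nothing available offers an explanation for this result. On these data alone, whether a methoxy group, an amine or a longer chain on this carbon would read the same remains open. So does whether hydroxy here would act alike with the charged chain of compound 2.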